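From Trifluoromethyl to Fluoro in a Growth Inhibition Series

The source may report more compounds than this note shows. Statements on the series, on what has been measured and on what is new or still open speak of the compounds shown alone.

Within the data shown here, in a functional assay on IGROV-1 cells (Homo sapiens) for inhibition (on this read-out higher numbers stand for weaker inhibition of growth and lower numbers for stronger inhibition of growth), compound 3 (`Nc1ccc(-c2nc3ccccc3s2)cc1C(F)(F)F`) gives 2600 nM, the only true number in this small set. Compound 1 (`Nc1ccc(-c2nc3cc(F)ccc3s2)cc1Cl`) reads < 10 nM, which is a limit and not a number. Compound 2 (`Nc1ccc(-c2nc3cc(F)ccc3s2)cc1I`) reads < 10 nM, which is also a limit. Compound 3 therefore stands on the weak side of both limits.

Compound 4 (`Nc1ccc(-c2nc3ccccc3s2)cc1F`) has not yet been measured. Its difference from compound 3 is fluoro in place of trifluoromethyl on an aromatic carbon, ortho to an amino group.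

Among the measured compounds shown here, the one measured step, a step that the two limits leave unreadable from compound 1 to compound 2, places iodo in place of chloro on an aromatic carbon, so it offers no size to carry over. The closest guide is compound 1, whose limit of < 10 nM comes with a single chloro where compound 4 has fluoro, although the core of compound 1 also differs, so the guide is loose.

The expected change in this assay is a 33-fold lower number from compound 3 to compound 4 (1.51 log units; beyond the scatter), towards stronger inhibition of growth, and this expectation is uncertain. For compound 4 the estimated value is 80 nM, with an expected range of 8 nM to 1500 nM.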

Compound 4, concentration for 50% growth inhibition: < 10 nM
Compound 4 was reported as a limit; the forecaster's own chance of this, stated with the estimate: 35%; middle value at least 8.0-fold (0.90 log units) away from the limit.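

At this position, on an aromatic carbon ortho to an amino group, the change from trifluoromethyl to fluoro gives an at least 260-fold lower number from compound 3 to compound 4 (2.41 log units; beyond the scatter) in this assay, towards stronger inhibition of growth and beyond the usual scatter. The value of compound 4, < 10 nM, is a limit and not a number. Among these compounds, the only earlier step at this position, iodo in place of chloro, cannot be read, which makes this the first readable sign in the set that the group placed here can shift growth inhibition by a large amount.

The real size of the step stays open, because compound 4 sits at the same limit as most of the set and gives no true number to measure from: the limit of < 10 nM in this assay, at which 3 of the 4 values shown sit.

Also open, on these data alone, is how other groups would behave at this position on the shared core of compound 3 and compound 4, for example a nitrile, a methoxy group or a carboxylic acid, and whether any of them would read more like fluoro or more like trifluoromethyl.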